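Vinyl for thiophen-3-yl: expected cytotoxicity of compound 4

This account rests on a few compounds, and the source may have more. Where it says the series, first, only, none or still open, it means among the compounds named here.

Compound 3 `C[C@H]1[C@H](NCc2cc(-c3ccsc3)cs2)C[C@H]2C[C@@H]1C2(C)C` gives 25000 nM in an ADME assay on MDCK cells (Canis lupus familiaris) for cytotoxicity, read by microscopy, with a stated time of 48 h (on this read-out lower numbers stand for higher toxicity in this test and higher numbers for lower toxicity in this test), and stands level with compound 1 `C[C@H]1[C@H](NCc2cccs2)C[C@H]2C[C@@H]1C2(C)C`, which gives 25000 nM. The step of no change at the digits printed from compound 1 to compound 3 (within the scatter) shows that adding thiophen-3-yl left the read-out unchanged. Compound 2 `C[C@H]1[C@H](NCc2cnccn2)C[C@H]2C[C@@H]1C2(C)C` sits at the limit of > 100000 nM in this assay, at which 1 of the 3 values shown sits, a limit rather than a number. In this assay compound 2 gives > 100000 nM. The only measured move beyond the scatter is an at least 4.0-fold higher number from compound 1 to compound 2 (0.60 log units; beyond the scatter), and it concerns the group on the chain carbon, not the aromatic ring. Compound 4 `C=Cc1csc(CN[C@@H]2C[C@H]3C[C@@H]([C@H]2C)C3(C)C)c1` carries vinyl in place of thiophen-3-yl on an aromatic carbon. Among the measured compounds shown here, this largely reverses an addition that produced no change, and no measured step involves vinyl. The step is therefore estimated as no change at the digits printed from compound 3 to compound 4 (within the scatter), within the scatter. Compound 4 is expected to give 25000 nM, between 12500 nM and 50000 nM.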

Compound 4, minimum cytotoxic concentration: 6250 nM
Compound 4: the middle estimate sits 4.0-fold (0.60 log units) above what was measured, outside the stated range (below it).
By their numbers in this assay, from the lowest: compound 4; then compounds 1 and 3 (each within the scatter of the next). At a limit, above all of these: compound 2.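

On the aromatic carbon two ring bonds from the ring sulfur, the substituent does matter in this assay: vinyl gives a 4.0-fold lower number from compound 3 to compound 4 (0.60 log units; beyond the scatter) and a 4.0-fold lower number from compound 1 to compound 4 (0.60 log units; beyond the scatter), which means higher toxicity in this test. The earlier lack of change with thiophen-3-yl therefore holds for that group and not for the position as a whole. No measurement shown bears on the cause of this shift.

As far as these compounds go, it remains open whether an ethyl or methyl group at this carbon would also lower the number, or whether the shift is specific to vinyl.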